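Inverting one ring stereocentre on an inactive hydroxylated analogue

This account rests on a few compounds, and the source may have more. Where it says the series, first, only, none or still open, it means among the compounds named here.

Compound 1 `Cc1cn([C@H]2C[C@H](O)[C@@H](CO)O2)c(=O)n(/C=C/C=O)c1=O` gives 500 nM in a functional assay on HeLa cells (Homo sapiens) for inhibition; a lower number here means a stronger inhibitor, a higher number a weaker inhibitor. Compound 2 `Cc1cn([C@@H]2O[C@H](CO)[C@@H](O)[C@H]2O)c(=O)n(/C=C/C=O)c1=O` reaches only the limit of this assay at > 100000 nM. The single difference between them, hydroxy in place of hydrogen on a saturated ring carbon, brings an at least 200-fold higher number from compound 1 to compound 2 (2.30 log units; beyond the scatter), a step whose true size is open-ended, as the limit of > 100000 nM in this assay, at which 1 of the 2 values shown sits. Compound 3 `Cc1cn([C@@H]2O[C@H](CO)[C@@H](O)[C@@H]2O)c(=O)n(/C=C/C=O)c1=O` keeps every atom and bond of compound 2 and differs from it only as follows: the two compounds have the same atoms and bonds and differ only in configuration as drawn: 1 of 5 stereo elements differ; a stereocentre at a saturated ring carbon is drawn R in compound 2 and S in compound 3. Among the measured compounds shown here, no measured step here concerns a change of configuration alone, so the only guide is that compound 2 already sits at the limit. Compound 3 is therefore expected to remain near that limit, with a number no higher from compound 2 to compound 3 (the limit leaves the size open) as the estimated step from compound 2. For compound 3 the expected value in this assay is 100000 nM, within a range of 20000 nM to 300000 nM.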

Compound 3, half-maximal inhibitory concentration: 40000 nM
Compound 3: the middle estimate sits 2.5-fold (0.40 log units) above what was measured; measured number inside the range.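

In this assay, going by these compounds, changing only the configuration at a saturated ring carbon gives an at least 2.5-fold lower number from compound 2 to compound 3 (0.39 log units; beyond the scatter), a step whose true size stays open: the limit of > 100000 nM in this assay, at which 1 of the 3 values shown sits. The hydroxy in place of hydrogen now has a step of readable size, an 80-fold higher number from compound 1 to compound 3 (1.90 log units; beyond the scatter), and a large loss remains with the configuration drawn in the more active of the two hydroxylated analogues. Configuration therefore accounts for part of the gap between the hydroxylated analogues, but it does not remove the loss from adding the hydroxy: the fact that compounds 2 and 3 differ only in the configuration as drawn.

On these data alone, what stays open is whether an amine or a methoxy group on this ring carbon would bring the number back toward that of compound 1 at 500 nM. How far the two configurations truly lie apart also cannot be read from these compounds.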